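Swapping a nitrile for propyl: what happens to cytotoxicity

The source may hold more compounds than are shown below. What is called first, only, known or untested is meant among the compounds shown, and "the series" means these compounds.

Of the compounds shown here, three sharing one core have been measured in a functional assay on MT2 cells (Homo sapiens) for cytotoxicity; on this read-out higher numbers stand for lower toxicity in this test and lower numbers for higher toxicity in this test. Compound 1 `CC(C)=CCOc1cc(Nc2nccs2)ccc1C#N` gives 500 nM, the second highest of the three numbers. Its nearest neighbour is compound 3 `CC(C)=CCOc1cc(Nc2ccccn2)ccc1C#N`, which gives 290 nM; the change a 1.7-fold lower number from compound 1 to compound 3 (0.24 log units; within the scatter) lies within the scatter, so these two compounds cannot be told apart on this read-out. Far away stands compound 2 `CC(C)=CCOc1cc(Nc2ncccn2)ccc1C`, which gives 78000 nM, a much higher number and therefore much lower toxicity; compound 2 differs from compound 1 in two places at once, so no single step links them.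

Compound 4 `CCCc1ccc(Nc2nccs2)cc1OCC=C(C)C` is not yet measured. Compared with compound 1 it shows this difference: propyl in place of cyano on an aromatic carbon. Among the measured compounds shown here, no measured step changes the cyano group alone, so nothing bears directly on this change. For the measured compounds named here, the only hint is that compound 2, which also lacks the cyano group, gives a far higher number than compound 1, but that comparison mixes in a second change. An upward step of uncertain size, meaning lower toxicity, is therefore expected, with wide uncertainty. Compound 4 is estimated at 5000 nM in this assay, within a range from 800 nM to 30000 nM, corresponding to an expected step of a 10-fold higher number from compound 1 to compound 4 (1.00 log units; beyond the scatter).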

Compound 4, half-maximal cytotoxic concentration: 23000 nM
Beside the measured number, compound 4's estimate is 4.6-fold (0.66 log units) below it, and the stated range covers the measured number.
By their numbers in this assay, from the lowest: compounds 3 and 1 (each within the scatter of the next); then compound 4; then compound 2.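

In this assay, the step for propyl in place of cyano, a 46-fold higher number from compound 1 to compound 4 (1.66 log units; beyond the scatter), is the first among these compounds to change this aromatic carbon alone, and it shows that this one substituent strongly affects the read-out: the higher number means lower toxicity in this test. The only other single change, a 1.7-fold lower number from compound 1 to compound 3 (0.24 log units; within the scatter), lies within the scatter, so among these compounds the swap on the aromatic carbon registers clearly while the swap on the nitrogen does not. Nothing available here accounts for the size of this step, so the numbers record the effect without explaining it.

A single replacement cannot separate what losing the cyano group contributes from what gaining the propyl group contributes, and the compounds shown do not reveal how an amine, a carboxylic acid or a longer chain such as hexyl would behave on the same carbon. Going by these compounds, it also remains open whether the same swap would produce a step of similar size in compound 3, which carries pyridin-2-yl on the nitrogen instead of 1,3-thiazol-2-yl.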